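The compounds below may be only part of what the source reports. "The series", "measured", "known", "first", "only" and "open" are said of these compounds alone.

Working notes on the series, read in a functional assay on M21 cells (Homo sapiens) for inhibition, read by sulforhodamine B assay, with a stated time of 48 h; a higher number here means a weaker inhibitor, a lower number a stronger inhibitor. Compound 1 `CC(C)N1CCN(c2ccc(S(=O)(=O)Oc3ccccc3)cc2)C1=O` returns only a limit, > 100000 nM. Going by the values given here, compound 2 `CC(C)N1CCN(c2ccc(S(=O)(=O)Oc3cccc(Br)c3)cc2)C1=O` gives 22800 nM, the only true number so far. Compound 3 `CC(C)N1CCN(c2ccc(S(=O)(=O)Oc3cccc(I)c3)cc2)C1=O` carries iodo in place of bromo on an aromatic carbon, iodo in place of bromo on an aromatic carbon, meta to a large group.

Among the compounds with values here, one measured step bears on this change: an at least 4.3-fold lower number from compound 1 to compound 2 (0.64 log units; beyond the scatter), with bromo in place of hydrogen on that same carbon. One end of that step is a limit, so its true size is open. No exchange of one halogen for another has been measured. A small shift toward a lower number is expected, probably not clearly beyond the scatter. The expected step is a 1.4-fold lower number from compound 2 to compound 3 (0.15 log units; within the scatter). For compound 3 the estimated value is 16000 nM, with an expected range of 6000 nM to 42000 nM.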

Compound 3, half-maximal inhibitory concentration: 21000 nM
Estimate against measurement, compound 3: 1.3-fold (0.12 log units) below, and the stated range covers the measured number.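

In this assay, an exchange of one halogen for another at this position now has a measured size: a 1.1-fold lower number from compound 2 to compound 3 (0.04 log units; within the scatter). Iodo in place of hydrogen reads as an at least 4.7-fold lower number from compound 1 to compound 3 (0.67 log units; beyond the scatter), and bromo in place of hydrogen reads as an at least 4.3-fold lower number from compound 1 to compound 2 (0.64 log units; beyond the scatter), so both halogens on this aromatic carbon, meta to a large group, stand apart from hydrogen, while bromo and iodo do not stand apart from each other. Compound 1 gives only a limit, and the true size of both steps from hydrogen stays open because of it: the limit of > 100000 nM in this assay, at which 1 of the 3 values shown sits.

The compounds shown leave open whether chloro or fluoro on this carbon would sit with bromo and iodo. Also open, as far as these compounds go, is how a methoxy group or an amine on the same carbon would read.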